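The source may hold more compounds than are shown below. What is called first, only, known or untested is meant among the compounds shown, and "the series" means these compounds.

Of the compounds shown here, two sharing one core have been measured in an assay on Prostate gland for inhibition of steroid 5-alpha-reductase (Rattus norvegicus); a lower number here means a stronger inhibitor, a higher number a weaker inhibitor. Compound 1 `C/C(=C\C(=O)Nc1ccccc1OCCCC(=O)O)c1ccc2c(ccn2C)c1` carries a methyl on its aromatic nitrogen, and in this assay compound 1 gives 780 nM. Compound 2 `C/C(=C\C(=O)Nc1ccccc1OCCCC(=O)O)c1ccc2c(ccn2C(C)c2ccccc2)c1` carries a 1-phenylethyl there instead, and in this assay compound 2 gives 19 nM. Among the compounds with values here, the single step between them, a 41-fold lower number from compound 1 to compound 2 (1.61 log units; beyond the scatter), is the only comparison available, and it places compound 2 at the lowest of the two numbers, with compound 1 as its nearest neighbour.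

Compound 3 `C/C(=C\C(=O)Nc1ccccc1OCCCC(=O)O)c1ccc2c(ccn2C(c2ccccc2)c2ccc(C(F)(F)F)cc2)c1` has not yet been measured. It differs from compound 2 by 4-(trifluoromethyl)phenyl in place of methyl on a saturated chain carbon bound to an aromatic carbon and an aromatic nitrogen. The change enlarges the group attached to that same nitrogen-bound carbon, the region where the earlier step from compound 1 to compound 2 brought its large gain. Within the data shown here, that step is the only guide, and it points toward a further lowering, though a repeat of so large a drop cannot be assumed; a smaller gain, or a change within the scatter, seems most likely. Compound 3 is therefore expected to give about 10 nM, between 3 nM and 40 nM. That estimate corresponds to a 1.9-fold lower number from compound 2 to compound 3 (0.28 log units; within the scatter).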

Compound 3, half-maximal inhibitory concentration: 8.1 nM
The estimate for compound 3 lay 1.2-fold (0.09 log units) above the measured number; low and high end bracket the measured number.
By their numbers in this assay, from the lowest: compound 3; then compound 2; then compound 1.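

In this assay, the saturated chain carbon bound to an aromatic carbon and an aromatic nitrogen accepts a much larger group without any loss: swapping methyl, with 1 heavy atom, for 4-(trifluoromethyl)phenyl, with 10 heavy atoms and an aromatic ring, gives a 2.3-fold lower number from compound 2 to compound 3 (0.37 log units; beyond the scatter). This shows that the number can still fall once this carbon already carries a phenyl ring, although this modest step is much smaller than the earlier 41-fold lower number from compound 1 to compound 2 (1.61 log units; beyond the scatter), so enlarging the group here does not repeat the earlier large gain. No supporting measurement is available to explain why either step occurs.

The compounds shown do not separate the contribution of the added ring from that of its trifluoromethyl group, and a plain phenyl in place of the 4-(trifluoromethyl)phenyl would draw that distinction. On these data alone, how far this tolerance extends also remains open, since a naphthyl group, or a phenyl ring carrying an amine or a carboxylic acid, could behave quite differently at this carbon.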